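The source may hold more compounds than are shown below. What is called first, only, known or untested is meant among the compounds shown, and "the series" means these compounds.

Working notes on the series.

The pair measured so far in a functional assay on HepG2 cells (Homo sapiens) for inhibition, read by MTT assay, with a stated time of 72 h (a higher number here means a weaker inhibitor, a lower number a stronger inhibitor), shares one core: compound 1 `CCc1ccccc1-n1cc(COc2cccc(NC(=O)Nc3ccc(Cl)c(C(F)(F)F)c3)c2)nn1` gives 3530 nM, and compound 2 `O=C(Nc1cccc(OCc2cn(-c3cccc(Cl)c3)nn2)c1)Nc1ccc(Cl)c(C(F)(F)F)c1` gives 2020 nM. Within the data shown here, the single step between them, a 1.7-fold lower number from compound 1 to compound 2 (0.24 log units; within the scatter), swaps the group on the aromatic nitrogen and stays within the scatter, so the two numbers cannot be ranked against each other; compound 2 simply holds one of two values that read as the same.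

Compound 3 `O=C(Nc1cccc(OCc2cn(-c3cccc(C(F)(F)F)c3)nn2)c1)Nc1ccc(Cl)c(C(F)(F)F)c1` is the next member. It differs from compound 2 in one place: trifluoromethyl in place of chloro on an aromatic carbon. Among the measured compounds shown here, no measured step touches a chloro-to-trifluoromethyl exchange on this ring. For the measured compounds named here, the only step on record, from compound 1 to compound 2, changes that same ring wholesale and still lands within the scatter, which is the sole guide here. The expectation for the exchange in this assay is therefore no movement beyond the scatter, in either direction, with the expected step being a 1.1-fold higher number from compound 2 to compound 3 (0.04 log units; within the scatter). Compound 3 is estimated at 2200 nM in this assay, with a range from 800 nM to 6000 nM.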

Compound 3, half-maximal inhibitory concentration: 1270 nM
Beside the measured number, compound 3's estimate is 1.7-fold (0.24 log units) above it; measured number inside the range.
By their numbers in this assay, from the lowest: compounds 3, 2 and 1 (each within the scatter of the next, the first and the last beyond it).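

In this assay, trifluoromethyl in place of chloro on an aromatic carbon, meta to a large group, gives a 1.6-fold lower number from compound 2 to compound 3 (0.20 log units; within the scatter), so this exchange joins the earlier change on the same ring in leaving the number within the scatter, and the two groups cannot be ranked at this position. Among these compounds, the new information lies in a 2.8-fold lower number from compound 1 to compound 3 (0.44 log units; beyond the scatter), the first step to pass beyond the scatter, though only modestly, with 3-(trifluoromethyl)phenyl in place of 2-ethylphenyl on the aromatic nitrogen; compound 2 remains within the scatter of both compound 1 and compound 3, so the series so far shows one modest separation rather than a graded trend. No measurement in hand bears on the origin of this separation.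

The step from 2-ethylphenyl to 3-(trifluoromethyl)phenyl changes both the group and its place on the ring, and the compounds shown cannot separate those two changes; 3-ethylphenyl would be the direct link. How an amine or a carboxylic acid at this position would read in this assay also remains open, since both groups shown here at that position are chloro and trifluoromethyl.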